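Alkyne substituent series: from trimethylsilyl to octyl

The compounds below may be only part of what the source reports. "The series", "measured", "known", "first", "only" and "open" are said of these compounds alone.

Compound 3 `CC(=O)Nc1nc(-c2cccc(NS(=O)(=O)c3ccc(C#C[Si](C)(C)C)cc3)c2)cs1` gives the highest number of the three measured in a functional assay on A-375 cells (Homo sapiens) for antiproliferative activity, read by trypan blue exclusion, with a stated time of 48 h, tested at 1 uM (a lower number here means a stronger effect, a higher number a weaker effect of the compound at the concentration tested), namely 94.3%. Compound 1 `CCCCCCC#Cc1ccc(S(=O)(=O)Nc2cccc(-c3csc(NC(C)=O)n3)c2)cc1` gives 40.7% in this assay, and compound 2 `CC(=O)Nc1nc(-c2cccc(NS(=O)(=O)c3ccc(C#CC4CCCCC4)cc3)c2)cs1` gives 52.3%. The steps of a number 53.6 percentage points higher from compound 1 to compound 3 (beyond the scatter) and a number 42 percentage points higher from compound 2 to compound 3 (beyond the scatter) both run towards the silicon-containing group, while a number 11.6 percentage points higher from compound 1 to compound 2 (beyond the scatter) is modest. Compound 4 `CCCCCCCCC#Cc1ccc(S(=O)(=O)Nc2cccc(-c3csc(NC(C)=O)n3)c2)cc1` differs from compound 3 by a group of 8 heavy atoms (8 carbon; no ring) in place of a group of 4 heavy atoms (3 carbon, 1 silicon; no ring), on a triple-bonded carbon. This change runs opposite to the two large steps, since the octyl chain resembles the hexyl of compound 1 with its 40.7% rather than the silicon group. A large drop in this assay is therefore expected, a number 54.3 percentage points lower from compound 3 to compound 4 (beyond the scatter). For compound 4 the estimated value in this assay is 40%, ranging from 20% to 65%.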

Compound 4, a percentage reported as activity, at one concentration (the size of the read-out at that concentration, not a potency): 39.6%
Estimate against measurement, compound 4: 0.4 percentage points above; low and high end bracket the measured number.
By their numbers in this assay, from the lowest: compounds 4 and 1 (each within the scatter of the next); then compound 2; then compound 3.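

With octyl on the triple-bonded carbon, the open chain matches the hexyl compound in this assay (a number 1.1 percentage points lower from compound 1 to compound 4 (within the scatter)), so the added chain length has no readable effect at this concentration. Octyl also separates from cyclohexyl (a number 12.7 percentage points lower from compound 2 to compound 4 (beyond the scatter)) and from the silicon-containing group (a number 54.7 percentage points lower from compound 3 to compound 4 (beyond the scatter)), so both open chains now share the same large gap to compound 3.

From the compounds shown here alone, whether a propyl chain, a dodecyl chain or a chain ending in an amine or a carboxylic acid would hold this level remains open. No supporting data are available to explain these differences.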